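The source may hold more compounds than are shown below. What is called first, only, known or untested is meant among the compounds shown, and "the series" means these compounds.

Within the data shown here, compound 2 `COc1cc(-n2cnn3cc(-c4ccc(Cl)cc4)cc3c2=O)ccc1OCC(OC(=O)[C@@H](N)C(C)C)C1CC1` stands lowest of the two numbers known in a functional assay on the whole organism (strain Sprague-Dawley) with Rattus norvegicus as the target, with a stated time of 4 days, at a dose of 30 mg/kg by the oral route (a higher number here means more inhibition at the dose given (going by the name of the read-out), a lower number less inhibition), where compound 2 gives 2.5%; compound 1 `COc1cc(-n2cnn3cc(-c4ccc(Cl)cc4)cc3c2=O)ccc1OCC(C)OC(=O)[C@@H](N)C(C)C` gives 7.6% in this assay, and the change a number 5.1 percentage points lower from compound 1 to compound 2 (within the scatter) lies within the scatter. Compound 3 `COc1cc(-n2cnn3cc(-c4ccc(Cl)cc4)cc3c2=O)ccc1OCC(C)(C)OC(=O)CN` differs from compound 2 by a group of 8 heavy atoms (5 carbon, 1 nitrogen, 2 oxygen; no ring) in place of a group of 12 heavy atoms (9 carbon, 1 nitrogen, 2 oxygen; one three-membered non-aromatic ring of carbon only), on a saturated chain carbon bound to an oxygen on an aromatic ring. Among the measured compounds shown here, only that one step bears on this change, and it was small, so the expected step of a number 2.5 percentage points higher from compound 2 to compound 3 (within the scatter) in this assay is none beyond the scatter. Compound 3 is therefore estimated at 5%, between -5% and 16%.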

Compound 3, a percentage reported as inhibition, in the whole organism at one dose (the size of the read-out at that dose, not a potency): 6.9%
For compound 3 the middle estimate is 1.9 percentage points below the measured one, and the stated range covers the measured number.
By their numbers in this assay, from the lowest: compounds 2, 3 and 1 (each within the scatter of the next).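

In this assay, placing the group of 8 heavy atoms with no ring on a saturated chain carbon bound to an oxygen on an aromatic ring gives a number 4.4 percentage points higher from compound 2 to compound 3 (within the scatter) and a number 0.7 percentage points lower from compound 1 to compound 3 (within the scatter). This position therefore accepts a whole-group exchange, not only the earlier single substituent change, without a step beyond the scatter. No measurement at hand explains this result. From the compounds shown here alone, it remains open whether a carboxylic acid or a longer chain at this place would give a step beyond the scatter.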